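The source may report more compounds than this note shows. Statements on the series, on what has been measured and on what is new or still open speak of the compounds shown alone.

Measured in an in vitro ADME assay on microsomes from liver (Homo sapiens) for metabolic stability; on this read-out higher numbers stand for fast clearance and lower numbers for slow clearance:
compound 1 `CC(C)S(=O)(=O)N(Cc1ccccc1-c1ccccc1)[C@H]1CCNC1`: 20 mL.min-1.g-1
compound 2 `CC(C)C(=O)N(Cc1ccccc1C(C)C)[C@H]1CCNC1`: < 7 mL.min-1.g-1 (a limit)
compound 3 `CC(C)CC(=O)N(Cc1ccccc1-c1ccccc1)[C@H]1CCNC1`: 9 mL.min-1.g-1

The result of compound 2 is < 7 mL.min-1.g-1 and is a limit of the assay and not a number. Compound 4 `CC(C)C(=O)N(Cc1ccccc1C(F)(F)F)[C@H]1CCNC1` has not yet been measured and differs from compound 2 in one group: trifluoromethyl in place of isopropyl on an aromatic carbon. Among the measured compounds shown here, this is trifluoromethyl in place of isopropyl on an aromatic carbon, and no measured pair shows that exchange. For the measured compounds named here, compound 3 supplies the only measured step, a 2.2-fold lower number from compound 1 to compound 3 (0.35 log units; beyond the scatter), which is modest and concerns isobutylcarbonyl in place of isopropylsulfonyl on an amine nitrogen. It therefore gives a rough size for a single exchange but no direction for this one, so no step beyond the scatter is expected in this assay. The estimated step is a number no lower from compound 2 to compound 4 (the limit leaves the size open). For compound 4 the expected value is 7 mL.min-1.g-1, with an estimated range from 4 mL.min-1.g-1 to 14 mL.min-1.g-1.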

Compound 4, intrinsic clearance in microsomes: < 7 mL.min-1.g-1
Compound 4 was reported as a limit; the forecaster's own chance of this, stated with the estimate: 50%; the middle value sits exactly at the limit.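

No step can be read from compound 2 to compound 4 in this assay, because both results are limits of the assay and not numbers: the limit of < 7 mL.min-1.g-1 in this assay, at which 2 of the 4 values shown sit. The compounds shown leave open what trifluoromethyl in place of isopropyl on an aromatic carbon does to clearance.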